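The source may report more compounds than this note shows. Statements on the series, on what has been measured and on what is new or still open speak of the compounds shown alone.

In a functional assay on MCF7 cells (Homo sapiens) for antiproliferative activity, read by MTT assay, with a stated time of 24 h (on this read-out lower numbers stand for stronger inhibition and higher numbers for weaker inhibition), compound 2 `CCCCCCSc1nnc(COc2cc(C)c3c(C)cc(=O)oc3c2)o1` reaches only the assay limit, > 100000 nM. Compound 1 `CCSc1nnc(COc2cc(C)c3c(C)cc(=O)oc3c2)o1` likewise stops at the limit, > 100000 nM. Both values sit at the limit of > 100000 nM in this assay, at which 2 of the 3 values shown sit. Compound 3 `Cc1cc(OCc2nnc(SCc3ccc(F)c(F)c3)o2)cc2oc(=O)cc(C)c12` gives a real number, 33300 nM, so that the step of an at least 3.0-fold lower number from compound 2 to compound 3 (0.47 log units; beyond the scatter) is at least modest, whereas the step that the two limits leave unreadable from compound 1 to compound 2 cannot be read. Compound 4 `CCCCCCS(=O)(=O)c1nnc(COc2cc(C)c3c(C)cc(=O)oc3c2)o1` differs from compound 2 by hexylsulfonyl in place of hexylsulfanyl on an aromatic carbon. Among the measured compounds shown here, none of the measured steps alters the sulfur-bearing group on that ring carbon, so no measured step bears directly on this change. For the measured compounds named here, the only guide is that compound 2 itself stops at the limit, > 100000 nM. Compound 4 is therefore expected to show no step beyond the scatter, a number no higher from compound 2 to compound 4 (the limit leaves the size open), and quite possibly to stop at the limit once more. Compound 4 is estimated at 100000 nM, in the range 30000 nM to 300000 nM.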

Compound 4, half-maximal inhibitory concentration: > 100000 nM
Compound 4: no number, only a limit; the forecaster's own chance of this, stated with the estimate: 70%; the middle value sits exactly at the limit.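

In this assay, hexylsulfonyl on this ring carbon leaves compound 4 at the assay limit, as hexylsulfanyl does for compound 2: the limit of > 100000 nM in this assay, at which 3 of the 4 values shown sit. The steps from compound 1 and from compound 2 to compound 4 cannot be read, so the change from sulfanyl to sulfonyl yields no real number on a hexyl chain. Among the compounds shown here, the one readable new step, with hexylsulfonyl in place of (3,4-difluorobenzyl)sulfanyl, is an at least 3.0-fold higher number from compound 3 to compound 4 (0.47 log units; beyond the scatter). On these data alone, it remains open whether a (3,4-difluorobenzyl)sulfonyl group would keep a real number, and whether an amine or a carboxylic acid on the hexyl chain would give one.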